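A few compounds are considered here, and "the series" means these few. Any claim that something is new, unique, unknown or untested is made for them only; others in the source may bear on it.

Measured so far in an assay on RKO cells for inhibition of ubiquitin carboxyl-terminal hydrolase 7 (Homo sapiens), read by a luciferase reporter, with a stated time of 18 h; on this read-out lower numbers stand for an effect already at smaller amounts and higher numbers for an effect only at larger amounts of compound:
compound 1 `Cc1cc(Cl)cc(-c2ccnc3cc(CN4C(=O)C5C(C4=O)C5(C)C)sc23)c1CC1CCCNC1` — 130 nM
compound 2 `Cc1cc(Cl)cc(-c2ccnc3cc(CN4C(=O)C5C(C4=O)C5(C)C)sc23)c1NC1CCCNC1` — 33 nM
compound 3 `Cc1cc(Cl)cc(-c2ccnc3cc(CN4C(=O)CCC4=O)sc23)c1CN1[C@@H](C)CNC[C@@H]1C` — 60 nM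

Compound 2 has the lowest number of the three; compound 3 lies within the scatter of it, compound 1 beyond it.

Compound 4 `Cc1cc(Cl)cc(-c2ccnc3cc(CN4C(=O)C5C(C4=O)C5(C)C)sc23)c1O[C@@H]1CCNC[C@@H]1C` carries (3-methylpiperidin-4-yl)oxy in place of (piperidin-3-yl)amino on an aromatic carbon. Among the measured compounds shown here, the only step that bears on a change at this position is a 3.9-fold lower number from compound 1 to compound 2 (0.60 log units; beyond the scatter), where the linking atom was exchanged. For the measured compounds named here, compound 4 exchanges the linking atom again and adds a methyl to the ring; no measured pair shows an oxygen-linked ring, so the direction is open. Compound 3 differs from compound 2 in several places and only its value can be compared.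

For compound 4 a step of a 2.1-fold higher number from compound 2 to compound 4 (0.33 log units; beyond the scatter) is expected, hardly beyond the scatter. The estimate for compound 4 is 70 nM, in a range from 20 nM to 250 nM.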

Compound 4, half-maximal effective concentration: 65 nM
Beside the measured number, compound 4's estimate is 1.1-fold (0.03 log units) above it, within the range that was stated.
By their numbers in this assay, from the lowest: compounds 2, 3, 4 and 1 (each within the scatter of the next, the first and the last beyond it).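

In this assay the position also accepts an oxygen-linked ring: with a 2.0-fold higher number from compound 2 to compound 4 (0.29 log units; within the scatter) and a 2.0-fold lower number from compound 1 to compound 4 (0.30 log units; within the scatter) both within the scatter, compound 4 cannot be separated from compound 2 or compound 1, although those two lie apart. The change alters the linking atom, the ring attachment and the methyl at once, so no single part can be read alone. No available evidence accounts for these numbers. Open, from the compounds shown here alone, is how the unmethylated (piperidin-4-yl)oxy group or an open-chain aminoethoxy group would compare here.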